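The source may report more compounds than this note shows. Statements on the series, on what has been measured and on what is new or still open speak of the compounds shown alone.

Compound 1 `O=C(CSc1nc(Nc2ccccc2)c2ccccc2n1)Nc1cccc(F)c1` and compound 2 `CCc1cccc(NC(=O)CSc2nc(Nc3ccccc3)c3ccccc3n2)c1` share one core and differ only in the group on the outer aromatic ring. In a functional assay on MDA-MB-231 cells (Homo sapiens) for inhibition, read by MTT assay, with a stated time of 72 h (a lower number here means a stronger inhibitor, a higher number a weaker inhibitor), compound 1 gives only a limit, > 50000 nM. Compound 2 reaches 12400 nM in this assay. The step of an at least 4.0-fold lower number from compound 1 to compound 2 (0.60 log units; beyond the scatter) shows that a change on that ring can move the number by at least that much, though the limit of > 50000 nM in this assay, at which 1 of the 2 values shown sits, leaves the true gap open. Compound 3 `O=C(CSc1nc(Nc2ccccc2)c2ccccc2n1)Nc1ccc(F)cc1` has the same atoms as compound 1, joined differently: 4-fluorophenyl in place of 3-fluorophenyl on an amide-type nitrogen. Going by the values given here, no measured step moves a fluorine from one place on this ring to another, so the measured step offers no direct guide, and the only fixed point is that compound 1 sits at the limit. Compound 3 is therefore expected to stay near that limit, with a step of a number no higher from compound 1 to compound 3 (the limit leaves the size open) not clearly beyond the scatter. The estimate for compound 3 is 50000 nM, between 15000 nM and 150000 nM.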

Compound 3, half-maximal inhibitory concentration: 34100 nM
Beside the measured number, compound 3's estimate is 1.5-fold (0.17 log units) above it; measured number inside the range.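

Compound 3 gives a fluorinated ring its first exact number in this assay, and moving the fluorine from 3-fluorophenyl to 4-fluorophenyl gives an at least 1.4-fold lower number from compound 1 to compound 3 (0.16 log units; that floor lies within the scatter). From the compounds shown here alone, compound 1 holds only a limit, so this move cannot be said to matter, and its true size stays open: the limit of > 50000 nM in this assay, at which 1 of the 3 values shown sits. With exact numbers at both ends, the comparison with the ethyl-bearing ring gives a 2.8-fold higher number from compound 2 to compound 3 (0.44 log units; beyond the scatter), although this step changes both the group and its place on the ring.

Whether the group or its place accounts for that last step stays open, and 4-ethylphenyl on the same amide-type nitrogen would separate the two. How a larger change to this ring would read, such as a carboxylic acid or an amine, is also unknown.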